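The compounds below may be only part of what the source reports. "The series", "measured", "known", "first", "only" and "open" are said of these compounds alone.

Compound 1 `COc1ccc(/C=C/C(=O)/C=C/c2ccc(OCc3cn(CCCCCOc4cc(=O)oc5ccccc45)nn3)c(OC)c2)cc1` was tested in a functional assay on PC-3 cells (Homo sapiens) for inhibition, read by sulforhodamine B assay, with a stated time of 48 h, tested at 50 uM (a higher number here means more inhibition of growth at the concentration tested, a lower number less inhibition of growth), where compound 1 was recorded as "not active" (no number reported), with no single number behind that verdict. Two related compounds give numbers in the same test: compound 2 `COc1cc(/C=C/C(=O)/C=C/c2cc(OC)c(OC)c(OC)c2)ccc1OCc1cn(CCCOc2cc(=O)oc3ccccc23)nn1` reaches 12%, and compound 3 `COc1ccc(/C=C/C(=O)/C=C/c2ccc(OCc3cn(CCOc4cc(=O)oc5ccccc45)nn3)c(OC)c2)cc1OC` reaches 19%; the gap between those two lies within the usual scatter, so neither can be called the more active of the pair. The shared core of compound 1 is kept in compound 4 `COc1cc(/C=C/C(=O)/C=C/c2ccco2)ccc1OCc1cn(CCCCCOc2cc(=O)oc3ccccc23)nn1`, which has not yet been measured. Among the compounds with values here, the one change is furan-2-yl in place of 4-methoxyphenyl on a double-bonded chain carbon bound to a double-bonded chain carbon. Within the data shown here, no measured pair shows the effect of this change, and compound 1 itself offers no number to step from, so the expectation rests on the low readings of the compounds that do have numbers. In this assay compound 4 is expected to show little growth inhibition, with any step from compound 1 expected to stay within the scatter rather than move clearly in either direction. The estimate for compound 4 is 12%, with a range from 0% to 30%.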

Compound 4, percent growth inhibition at one concentration: "not active" (no number reported)
The entry for compound 4 holds no number; no gap can be computed for the estimate.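

Within the data shown here, compound 1 and compound 4 are both recorded as not active, with no number behind either verdict, so no step between them can be read. On these data alone, how far furan-2-yl in place of 4-methoxyphenyl shifts growth inhibition, if at all, stays open. No supporting evidence bears on this result.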